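Para-chloro on the amide-ring phenyl of compound 1

A few compounds are considered here, and "the series" means these few. Any claim that something is new, unique, unknown or untested is made for them only; others in the source may bear on it.

Compound 1 `O=C1COc2ccc(-c3cccc(NS(=O)(=O)c4ccc(F)cc4)c3)cc2N1c1ccccc1` — 17700 nM
Compound 2 `O=C1COc2ccc(-c3ccc(O)cc3)cc2N1` — > 40000 nM
Compound 3 `COc1cccc(N2C(=O)COc3ccc(-c4ccc(O)cc4)cc32)c1` — > 40000 nM

Of the compounds shown here, three sharing the same core have been measured in a functional assay on HeLa cells (Homo sapiens) for antiproliferative activity, read by MTT assay, with a stated time of 72 h; on this read-out lower numbers stand for stronger inhibition and higher numbers for weaker inhibition. Within the data shown here, compound 1 gives 17700 nM there, and it is the only compound of the three with a number. In this assay compound 2 reaches only a limit, > 40000 nM. Compound 3 likewise reaches only a limit, > 40000 nM. Among the measured compounds shown here, the single step between measured neighbours, a step that the two limits leave unreadable from compound 2 to compound 3, is therefore unreadable, as both ends sit at the limit of > 40000 nM in this assay, at which 2 of the 3 values shown sit. For the measured compounds named here, no measured step bears directly on the change now considered.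

Compound 4 `O=C1COc2ccc(-c3cccc(NS(=O)(=O)c4ccc(F)cc4)c3)cc2N1c1ccc(Cl)cc1` differs from compound 1 in one place: chloro in place of hydrogen on an aromatic carbon. Going by the values given here, nothing among the measured compounds tells how substitution on this phenyl ring shifts the read-out, so the expectation rests on the value of compound 1 alone. The expected step in this assay, a 1.4-fold lower number from compound 1 to compound 4 (0.13 log units; within the scatter), is estimated to stay within the usual scatter, with no direction favoured. For compound 4 the estimated value in this assay is 13000 nM, with a range from 5000 nM to 32000 nM.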

Compound 4, half-maximal inhibitory concentration: 35000 nM
Estimate against measurement, compound 4: 2.7-fold (0.43 log units) below, and the stated range ends below it.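

In this assay, among these compounds, the change from phenyl to 4-chlorophenyl provides the first readable step at this phenyl ring on the amide-type nitrogen, a 2.0-fold higher number from compound 1 to compound 4 (0.30 log units; within the scatter). Among the compounds shown here, at this place, para to a large group, a chloro in place of hydrogen therefore cannot be told apart from hydrogen on this read-out, and the single step gives no direction for substitution on this ring in general. Compound 2 and compound 3 give only limits and not numbers, so their step cannot be read and neither compound adds to this comparison, and the read-out of this series stops at that limit: the limit of > 40000 nM in this assay, at which 2 of the 4 values shown sit.

Going by these compounds, it remains open whether a different group at the same place, such as an amine or a carboxylic acid in place of the chloro, would move the number beyond the usual scatter in either direction. Also open is how the remaining parts of compound 1 bear on the antiproliferative read-out, since no readable step among the compounds shown touches them.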